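Swapping the pyrrole for a furan on the carbonyl

The source may hold more compounds than are shown below. What is called first, only, known or untested is meant among the compounds shown, and "the series" means these compounds.

Compound 1 `O=C(/C=C/c1cccc([N+](=O)[O-])c1)c1ccc[nH]1`: 23000 nM
Compound 2 `COc1cccc(/C=C/C(=O)c2ccc[nH]2)c1`: 24000 nM
Compound 3 `O=C(/C=C/c1cc([N+](=O)[O-])ccc1Cl)c1ccc[nH]1`: 55000 nM

Three enone compounds have been tested in a functional assay on PC-3 cells (Homo sapiens) for inhibition, read by MTT assay, with a stated time of 48 h; a higher number here means a weaker inhibitor, a lower number a stronger inhibitor. Compound 1 gives the lowest of the three numbers; the change from compound 1 to compound 2 a 1.0-fold higher number from compound 1 to compound 2 (0.02 log units; within the scatter) does not take the value out of the scatter, while the change from compound 1 to compound 3 a 2.4-fold higher number from compound 1 to compound 3 (0.38 log units; beyond the scatter) is a modest shift toward a weaker inhibitor. Going by the values given here, no compound can be called the strongest on these numbers.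

Compound 4 `O=C(/C=C/c1cccc([N+](=O)[O-])c1)c1ccco1` is not yet measured. It differs from compound 1 in one place: furan-2-yl in place of 1H-pyrrol-2-yl on a carbonyl carbon. Neither measured step touches this end of the molecule; both vary the aromatic ring at the far end of the double bond, and together they show that changes there move the number by a small amount at most. For the present change nothing comparable exists, so the expectation rests on the general stability of this assay across the three compounds.

The author expects compound 4 to land close to compound 1 in this assay, with a step of a 1.3-fold higher number from compound 1 to compound 4 (0.12 log units; within the scatter) that may drift toward a weaker inhibitor. The estimate for compound 4 is 30000 nM, with a range from 10000 nM to 90000 nM.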

Compound 4, half-maximal inhibitory concentration: 14000 nM
For compound 4 the middle estimate is 2.1-fold (0.33 log units) above the measured one; the range from low to high includes it.
By their numbers in this assay, from the lowest: compounds 4, 1 and 2 (each within the scatter of the next); then compound 3.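

In this assay, the carbonyl end of the molecule now has a measured step of its own: furan-2-yl in place of 1H-pyrrol-2-yl on a carbonyl carbon gives a 1.6-fold lower number from compound 1 to compound 4 (0.22 log units; within the scatter). The exchange keeps the count of heavy atoms and the five-membered aromatic ring, while trading the hydrogen-bond donor of 1H-pyrrol-2-yl for the hydrogen-bond acceptor of furan-2-yl, and the step stays within the scatter. On this single pair, then, the assay does not separate the two groups at this position, and no measured evidence is available here to bear on this result.

From the compounds shown here alone, this comparison rests on the nitro-bearing aromatic ring of compound 1 alone, so it remains open whether furan-2-yl would give a similar step alongside the methoxy group of compound 2 or the chloro and nitro groups of compound 3. Also open, going by these compounds, is what a group of a different kind on the carbonyl carbon, such as a dimethylamino group or a longer alkyl chain, would do to the number.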